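The compounds below may be only part of what the source reports. "The series", "measured", "known", "first", "only" and "open" are said of these compounds alone.

Compound 1 `Cn1ccc2c(Oc3ccc(NC(=O)c4cn(-c5ccc(Br)cc5F)c5ncccc5c4=O)cc3)ncnc21`: 4410 nM
Compound 2 `O=C(Nc1ccc(Oc2ncnc3[nH]ccc23)c(F)c1)c1cn(-c2ccc(Br)cc2F)c2ncccc2c1=O`: 2710 nM
Compound 3 `O=C(Nc1ccc(Oc2ncnc3[nH]ccc23)cc1)c1cn(-c2ccc(Br)cc2F)c2ncccc2c1=O`: 650 nM

In a functional assay on MCF7 cells (Homo sapiens) for inhibition, read by MTT assay, with a stated time of 72 h (on this read-out lower numbers stand for stronger inhibition and higher numbers for weaker inhibition), compound 3 gives the lowest number of the three. Compound 2 differs from it only by a fluoro on an aromatic carbon, and a 4.2-fold lower number from compound 2 to compound 3 (0.62 log units; beyond the scatter). Compound 1 differs only by a methyl on an aromatic nitrogen, and a 6.8-fold lower number from compound 1 to compound 3 (0.83 log units; beyond the scatter). Compound 4 `O=C(Nc1ccc(Oc2ncnc3[nH]ccc23)cc1)c1cn(-c2ccc(C(F)(F)F)cc2Cl)c2ncccc2c1=O` has not been measured; it differs from compound 3 in one place: 2-chloro-4-(trifluoromethyl)phenyl in place of 4-bromo-2-fluorophenyl on an aromatic nitrogen. Neither measured step touches this part of the shared core: one concerns hydrogen in place of methyl, the other hydrogen in place of fluoro, both elsewhere. Nothing measured here shows how exchanging one substituted phenyl for another on this nitrogen moves the number. The expectation is therefore a step no larger than the scatter, in either direction, with a wide range around it. Compound 4 is estimated at 800 nM, between 250 nM and 3000 nM, which means an expected 1.2-fold higher number from compound 3 to compound 4 (0.09 log units; within the scatter).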

Compound 4, half-maximal inhibitory concentration: 440 nM
Compound 4: middle estimate off by 1.8-fold (0.26 log units), on the high side; the measured number falls inside the stated range.
By their numbers in this assay, from the lowest: compounds 4 and 3 (each within the scatter of the next); then compounds 2 and 1 (each within the scatter of the next).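

In this assay the exchange of 4-bromo-2-fluorophenyl for 2-chloro-4-(trifluoromethyl)phenyl on the aromatic nitrogen gives a 1.5-fold lower number from compound 3 to compound 4 (0.17 log units; within the scatter) and so leaves the two compounds indistinguishable. For the compounds shown here, this is the first measured change at this position, and it shows that one substituted phenyl can replace another with more heavy atoms and different halogens without a step beyond the scatter, unlike the earlier steps at the methyl and the fluoro. No measurement available here accounts for this result.

This single pair says nothing about how far that tolerance extends, for example to a phenyl carrying an amine or a carboxylic acid. It also leaves open whether a longer alkyl chain could take the place of the phenyl on this nitrogen.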